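The source may report more compounds than this note shows. Statements on the series, on what has been measured and on what is new or still open speak of the compounds shown alone.

Measured compounds:
- compound 1 `COc1ccc(-c2nc(CNc3ccc(C(=O)NO)cc3)n(-c3ccccc3)n2)cc1`: 77.6%
- compound 2 `O=C(NO)c1ccc(NCc2nc(-c3ccc(F)cc3)nn2-c2ccccc2)cc1`: 70.9%

In an assay on Sf9 cells for inhibition of protein deacetylase HDAC6 (Homo sapiens), read by fluorescence, with a stated time of 40 min, tested at 100 nM (a higher number here means more inhibition at the concentration tested (going by the name of the read-out), a lower number less inhibition), compound 2 gives 70.9%, the lower of the two numbers, yet the step of a number 6.7 percentage points lower from compound 1 to compound 2 (within the scatter) is within the scatter, so the two compounds are not separated. Compound 3 `O=C(NO)c1ccc(NCc2nc(-c3cc4ccccc4s3)nn2-c2ccccc2)cc1` differs from compound 2 by 1-benzothiophen-2-yl in place of 4-fluorophenyl on an aromatic carbon. Among the compounds with values here, the one measured step, a number 6.7 percentage points lower from compound 1 to compound 2 (within the scatter), also alters the group at this ring position and stayed within the scatter; it gives no basis for expecting a shift beyond the scatter here. Compound 3 is therefore expected at 70%, range 50% to 88%, an estimated step of a number 0.9 percentage points lower from compound 2 to compound 3 (within the scatter).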

Compound 3, a percentage reported as inhibition, at one concentration (the size of the read-out at that concentration, not a potency): 65.5%
Compound 3: the middle estimate sits 4.5 percentage points above what was measured; measured number inside the range.
By their numbers in this assay, from the lowest: compounds 3, 2 and 1 (each within the scatter of the next, the first and the last beyond it).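

In this assay the change from 4-fluorophenyl to 1-benzothiophen-2-yl reads a number 5.4 percentage points lower from compound 2 to compound 3 (within the scatter) and does not separate the pair, so this position accepts a two-ring aromatic group in place of a single aromatic ring with no resolved change. Against the 4-methoxyphenyl group, the same entrant gives a number 12.1 percentage points lower from compound 1 to compound 3 (beyond the scatter) as the first step at this position beyond the scatter, though only a modest one. Nothing available explains either step.
Open: whether an amine or a carboxylic acid on the aromatic ring at this position keeps the inhibition, and whether these single-concentration numbers track potency.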